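Aryl in place of isobutyl on the shared core

The compounds below may be only part of what the source reports. "The series", "measured", "known", "first", "only" and "open" are said of these compounds alone.

Measured so far:
compound 1 `CC(C)Cc1ccc2c(NCCCNCc3ccco3)ccnc2c1` — 23 10^-6 cm/s
compound 2 `COc1ccc(F)cc1CNCCCNc1ccnc2cc(CC(C)C)ccc12` — 23 10^-6 cm/s
compound 3 `COc1cccc(CNCCCNc2ccnc3cc(-c4ccccc4)ccc23)c1O` — 237 10^-6 cm/s

In an ADME assay for permeability, using PAMPA, with a stated time of 30 min, at pH 7.4 (a lower number here means that the compound crosses the layer more slowly, a higher number that the compound crosses the layer faster), compound 1 gives 23 10^-6 cm/s and compound 2 gives 23 10^-6 cm/s; the two stand level, together the lowest of the three numbers. Compound 3 gives 237 10^-6 cm/s, the highest of the set and well beyond the scatter from compound 2. Among the measured compounds shown here, the one single-point step at hand, no change at the digits printed from compound 1 to compound 2 (within the scatter), shows that swapping the group on the saturated chain carbon bound to the amine nitrogen left the number where it was.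

Compound 4 `COc1ccc(-c2ccc3c(NCCCNCc4cc(F)ccc4OC)ccnc3c2)cc1` keeps the chain and the 5-fluoro-2-methoxyphenyl of compound 2 and changes only the core substituent: 4-methoxyphenyl in place of isobutyl on an aromatic carbon. For the measured compounds named here, compound 3 differs from compound 2 in two places, so no clean step exists for the aryl-for-isobutyl swap; still, since the benzyl change in no change at the digits printed from compound 1 to compound 2 (within the scatter) did nothing, the gap between compound 2 and compound 3 is most plausibly carried by the aryl group on the core. An upward step is therefore expected, of about a 6.5-fold higher number from compound 2 to compound 4 (0.81 log units; beyond the scatter). Compound 4 is estimated at 150 10^-6 cm/s, with a range of 50 10^-6 cm/s to 400 10^-6 cm/s.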

Compound 4, apparent permeability: 237 10^-6 cm/s
Compound 4: middle estimate off by 1.6-fold (0.20 log units), on the low side; measured number inside the range.
By their numbers in this assay, from the lowest: compounds 1 and 2 (each within the scatter of the next); then compounds 3 and 4 (each within the scatter of the next).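

In this assay, putting 4-methoxyphenyl in place of isobutyl on an aromatic carbon of the shared core gives a 10-fold higher number from compound 2 to compound 4 (1.01 log units; beyond the scatter), with the chain and the 5-fluoro-2-methoxyphenyl held constant. Among the compounds shown here, the earlier single-place step, at the other end of the molecule, gave no change at the digits printed from compound 1 to compound 2 (within the scatter), so this result is the first to show that the number responds to a change in one place, and that this place on the core is where it does so. No measurement bears on why the swap has this effect, so the step stands as an observation about these two structures only.

The compounds shown leave open whether the step needs the methoxy group or whether a plain phenyl, a pyridine ring or a carboxylic acid on the ring would give a similar number, and whether a shorter alkyl group such as methyl would stay level with isobutyl. They also leave open whether the same swap gives a step of this size with furan-2-yl at the far end of the chain, as in compound 1.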